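A few compounds are considered here, and "the series" means these few. Any claim that something is new, unique, unknown or untested is made for them only; others in the source may bear on it.

The measured compounds are three. Compound 1 is `C=C(Br)C(=O)Nc1cccc(/C=C2\SC(=O)N(Cc3ccc(C(F)(F)F)cc3)C2=O)c1` and gives 870 nM in a functional assay on FM3A cells (Mus musculus) for cytotoxicity, read by cell counting, with a stated time of 2 days; on this read-out lower numbers stand for stronger inhibition and higher numbers for weaker inhibition. Compound 2 is `Nc1ccc(/C=C2\SC(=O)N(Cc3ccc(F)cc3)C2=O)cc1` and gives 36000 nM. Compound 3 is `Nc1ccc(/C=C2\SC(=O)N(Cc3cccc(F)c3)C2=O)cc1` and gives 121000 nM.

Among these, compound 1 stands lowest, and its distance from both other compounds is beyond the scatter, so it is the most potent of the three in this assay. Compound 4 is `C=C(Br)C(=O)Nc1cccc(/C=C2\SC(=O)N(Cc3ccccc3)C2=O)c1`. It differs from compound 1 in one place: hydrogen in place of trifluoromethyl on an aromatic carbon, a hydrogen in place of trifluoromethyl on an aromatic carbon. For the measured compounds named here, no measured step repeats exactly this change. Going by the values given here, the one measured step, a 3.4-fold higher number from compound 2 to compound 3 (0.53 log units; beyond the scatter), exchanges one fluorophenyl for another on the same kind of saturated chain carbon bound to an amide-type nitrogen; it was modest and shows that changes on this ring can shift the number, though it says nothing directly about removing a trifluoromethyl. With no closer guide, the expectation for compound 4 is a small step, likely toward a somewhat higher number, a 1.7-fold higher number from compound 1 to compound 4 (0.24 log units; within the scatter). The estimated value for compound 4 is 1500 nM, with a range from 500 nM to 5000 nM.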

Compound 4, half-maximal inhibitory concentration: 810 nM
The estimate for compound 4 lay 1.9-fold (0.27 log units) above the measured number; the range from low to high includes it.
By their numbers in this assay, from the lowest: compounds 4 and 1 (each within the scatter of the next); then compound 2; then compound 3.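

In this assay, putting hydrogen where trifluoromethyl stood gives a 1.1-fold lower number from compound 1 to compound 4 (0.03 log units; within the scatter), so 4-(trifluoromethyl)phenyl and phenyl cannot be told apart in this cell assay when the rest of compound 1 is kept. The earlier step, a 3.4-fold higher number from compound 2 to compound 3 (0.53 log units; beyond the scatter), showed only that moving a fluorine around this ring can matter in a different pair of compounds; the new pair shows that a group of four heavy atoms on this aromatic carbon, para to a large group, can be replaced by plain hydrogen with no shift beyond the scatter. Nothing available here offers a reason for this result.

Going by these compounds, this is one pair, so it describes only these two compounds and sets no general rule for the position, and it is unknown whether the same would hold with the amine-bearing ring of compound 2 in place of the bromine-bearing side of compound 1. On these data alone, it also remains open whether a carboxylic acid, an amine or a longer chain at this same aromatic carbon would leave the number just as unmoved, or would finally shift it.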